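Methoxy in Place of Hydrogen on a Coumarin-Triazole Series

The source may report more compounds than this note shows. Statements on the series, on what has been measured and on what is new or still open speak of the compounds shown alone.

Of the compounds shown here, three have been tested in a functional assay on SW480 cells (Homo sapiens) for antiproliferative activity, read by MTT assay, with a stated time of 48 h; a lower number here means a stronger inhibitor, a higher number a weaker inhibitor. Compound 1 `COC(=O)c1ccccc1OCc1cn(-c2cc(=O)oc3ccc(Br)cc23)nn1` gives 20200 nM. Compound 2 `O=c1cc(-n2cc(COc3ccc(F)cc3)nn2)c2cc(Br)ccc2o1` gives 1770 nM, and compound 3 `O=c1cc(-n2cc(COc3ccc(F)cc3)nn2)c2ccccc2o1` gives 3820 nM. Among these three numbers compound 3 stands second highest: its nearest neighbour is compound 2, and the step of a 2.2-fold higher number from compound 2 to compound 3 (0.33 log units; beyond the scatter) shows that removing the bromo raised the number modestly, beyond the scatter, while compound 1 lies furthest away with a far higher number.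

Compound 4 `COc1ccc2oc(=O)cc(-n3cc(COc4ccc(F)cc4)nn3)c2c1` has not yet been measured. It differs from compound 3 by methoxy in place of hydrogen on an aromatic carbon. Among the measured compounds shown here, no measured pair exchanges hydrogen for methoxy, so the only step that bears on the change is a 2.2-fold higher number from compound 2 to compound 3 (0.33 log units; beyond the scatter), which shows that a substituent on an aromatic carbon of the shared core can shift the number by a modest amount. A methoxy group may not behave as bromo does, so the expectation is for at most a modest shift, with a small lowering of the number considered somewhat more likely than a rise, or no change beyond the scatter. The expected step is a 1.4-fold lower number from compound 3 to compound 4 (0.13 log units; within the scatter). The estimate for compound 4 in this assay is 2800 nM, with a range from 1000 nM to 8000 nM.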

Compound 4, half-maximal inhibitory concentration: 25900 nM
Compound 4: middle estimate off by 9.3-fold (0.97 log units), on the low side; the whole stated range lies below it.
By their numbers in this assay, from the lowest: compound 2; then compound 3; then compounds 1 and 4 (each within the scatter of the next).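

In this assay, the aromatic carbon of the shared core that carries bromo in compound 2 proves able to move the number in either direction: methoxy in place of hydrogen gives a 6.8-fold higher number from compound 3 to compound 4 (0.83 log units; beyond the scatter), opposite in direction to the lowering that bromo brings relative to hydrogen. Methoxy in place of bromo at that same carbon gives a 15-fold higher number from compound 2 to compound 4 (1.17 log units; beyond the scatter), the largest of the steps among compounds that differ in one place, so the choice of group here matters more than the earlier pair alone could show. Nothing available explains why methoxy and bromo part ways at this carbon.

With only hydrogen, bromo and methoxy seen at this position, the compounds shown leave open whether the rise is particular to methoxy or would also follow from a hydroxyl, an amine or a longer chain such as ethoxy. Among the compounds shown here, they also leave open whether methoxy would raise the number in the same way on another aromatic carbon of the core, or with the side chain of compound 1 in place of the one shared by compound 3 and compound 4.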